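The compounds below may be only part of what the source reports. "The series", "measured", "known", "first", "only" and "open" are said of these compounds alone.

In a functional assay on MDA-MB-231 cells (Homo sapiens) for inhibition, read by MTT assay, with a stated time of 48 h (a lower number here means a stronger inhibitor of growth, a higher number a weaker inhibitor of growth), compound 1 (`Cc1cccc(Nc2ncnc3ccc(NC(=S)NCc4ccccc4)cc23)c1`) gives 19500 nM and compound 2 (`CCc1cccc(Nc2ncnc3ccc(NC(=S)NCc4ccccc4)cc23)c1`) gives 10500 nM while compound 3 (`CC(C)c1ccc(Nc2ncnc3ccc(NC(=S)NCc4ccccc4)cc23)cc1`) gives 12800 nM with all three lying within the scatter of one another. Compound 3 sits close to both others (a 1.2-fold higher number from compound 2 to compound 3 (0.09 log units; within the scatter)) and (a 1.5-fold lower number from compound 1 to compound 3 (0.18 log units; within the scatter)). Compound 4 (`CC(C)(C)c1ccc(Nc2ncnc3ccc(NC(=S)NCc4ccccc4)cc23)cc1`) takes methyl in place of hydrogen on a saturated chain carbon bound to an aromatic carbon and two saturated chain carbons, so isopropyl becomes tert-butyl (methyl in place of hydrogen on a saturated chain carbon bound to an aromatic carbon and two saturated chain carbons). For the measured compounds named here, the nearest precedent, a methyl added on a saturated chain carbon (a 1.9-fold lower number from compound 1 to compound 2 (0.27 log units; within the scatter)), stayed within the scatter, so no step beyond it is expected in this assay here. The expected step is small (a 1.2-fold lower number from compound 3 to compound 4 (0.07 log units; within the scatter)). Compound 4 is estimated at 11000 nM with an expected range from 5500 nM to 22000 nM in this measurement.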

Compound 4, concentration for 50% growth inhibition: 8700 nM
The estimate for compound 4 lay 1.3-fold (0.10 log units) above the measured number, within the range that was stated.
By their numbers in this assay, from the lowest: compounds 4, 2, 3 and 1 (each within the scatter of the next, the first and the last beyond it).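

In this assay, methyl in place of hydrogen, turning isopropyl into tert-butyl, gives a 1.5-fold lower number from compound 3 to compound 4 (0.17 log units; within the scatter), so this change stays small on a more branched carbon as well: the same change on two cores in this assay, a 1.9-fold lower number (0.27 log units; within the scatter) from compound 1 to compound 2 and a 1.5-fold lower number (0.17 log units; within the scatter) from compound 3 to compound 4, 1.3-fold (0.10 log units) apart, within the scatter of two such steps Taking 4-(tert-butyl)phenyl in place of 3-ethylphenyl gives a 1.2-fold lower number from compound 2 to compound 4 (0.08 log units; within the scatter). Taking it in place of 3-methylphenyl gives a 2.2-fold lower number from compound 1 to compound 4 (0.35 log units; beyond the scatter), the only step among these compounds beyond the scatter, and a modest one.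

As far as these compounds go, all the groups on this phenyl ring are plain hydrocarbon chains, so what an amine or a carboxylic acid in place of tert-butyl would do stays open.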